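The source may hold more compounds than are shown below. What is called first, only, known or untested is meant among the compounds shown, and "the series" means these compounds.

Series notes. Compound 1 `COc1ccc2[nH]c(-c3ccccc3)c(C=C(C#N)C#N)c2c1` and compound 2 `COc1ccc(-c2[nH]c3ccc(OC)cc3c2C=C(C#N)C#N)cc1` share a core and differ only by hydrogen in place of methoxy on an aromatic carbon. Compound 3 `COc1ccc2[nH]c(-c3ccccc3)c(/C=C(\C#N)S(=O)(=O)c3ccccc3)c2c1` carries a different side chain on the indole side, and compound 4 `N#C/C(=C\c1c(-c2ccccc2)[nH]c2ccccc12)S(=O)(=O)c1ccccc1` is its counterpart lacking the methoxy group, a difference set out as hydrogen in place of methoxy on an aromatic carbon. In a functional assay on NCI/ADR-RES cells (Homo sapiens) for inhibition, read by sulforhodamine B assay, with a stated time of 48 h (a higher number here means a weaker inhibitor of growth, a lower number a stronger inhibitor of growth), compound 2 gives 403 nM, compound 1 gives 2800 nM, and compound 3 gives 3800 nM. Among the compounds with values here, the one measured step is a 6.9-fold higher number from compound 2 to compound 1 (0.84 log units; beyond the scatter). The numbers of compound 3 and compound 1 lie within the scatter of each other, while compound 3 stands well apart from compound 2; the difference between the cores of compound 3 and compound 2 is not broken down here.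

The change from compound 3 to compound 4 is the same kind of change as that from compound 2 to compound 1, hydrogen in place of methoxy on an aromatic carbon, but not the same change. In the earlier pair the place is on a six-membered aromatic ring of carbon only, para to a large group; in compound 3 the place is part of a fused or bridged system of two rings, meta to a fused ring and para to a fused ring. The earlier step of a 6.9-fold higher number from compound 2 to compound 1 (0.84 log units; beyond the scatter) therefore comes from a different place and guides the new pair only loosely. The expected step in this assay is a 1.7-fold higher number from compound 3 to compound 4 (0.23 log units; within the scatter), a smaller move in the same direction. Compound 4 is estimated at 6500 nM, with an expected range from 2500 nM to 17000 nM.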

Compound 4, concentration for 50% growth inhibition: 1100 nM
The estimate for compound 4 lay 5.9-fold (0.77 log units) above the measured number; the whole stated range lies above it.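

In this assay, hydrogen in place of methoxy on an aromatic carbon gives a 3.5-fold lower number from compound 3 to compound 4 (0.54 log units; beyond the scatter) and so lowers the number on this core, whereas the same kind of change raised it on the core of compound 1. Set side by side, the two steps run in opposite directions, and the change does not carry from one core to the other in this series: the same change on two cores in this assay, a 6.9-fold higher number (0.84 log units; beyond the scatter) from compound 2 to compound 1 and a 3.5-fold lower number (0.54 log units; beyond the scatter) from compound 3 to compound 4, 24-fold (1.38 log units) apart, beyond the scatter of two such steps. With only these two pairs, which differ both in the side chain and in where the methoxy group sits, the data do not show which of these differences accounts for the gap, and they give no general rule for this change.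

Still open, from the compounds shown here alone, is how this aromatic carbon of the fused system of two rings reads with a group other than methoxy or hydrogen, such as a hydroxyl, a fluorine or an amine, which would show whether the step is tied to methoxy itself. Also open, going by these compounds, is how hydrogen in place of methoxy at this same place reads with the side chain of compound 1, a pair that would separate the effect of place from that of side chain.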